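The source may hold more compounds than are shown below. What is called first, only, known or untested is meant among the compounds shown, and "the series" means these compounds.

Measured so far:
compound 1, `Fc1ccc(-c2csc(N/N=C/c3ccc(Cl)cc3Cl)n2)cc1`: 90.7%
compound 2, `Fc1ccc(-c2csc(N/N=C/c3cccs3)n2)cc1`: 92.4%
compound 3, `COC(=O)c1cc(-c2csc(N/N=C/c3ccc(Cl)cc3Cl)n2)ccc1OCc1ccccc1`: 19.2%

In a functional assay, read by spectrophotometry, with a stated time of 15 min, tested at 20 ug/mL (on this read-out higher numbers stand for a stronger effect at the one concentration tested and lower numbers for a weaker effect), compound 1 gives 90.7%. Compound 2 gives 92.4%, a number within the scatter of compound 1, so the two cannot be told apart. Compound 3 gives 19.2%, far below compound 1 and well beyond the scatter, leaving compound 1 among the upper pair of the three.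

Compound 4, `COc1ccc(-c2csc(N/N=C/c3ccc(Cl)cc3Cl)n2)cc1`, differs from compound 1 in one place: methoxy in place of fluoro on an aromatic carbon. Among the compounds with values here, no measured pair shows this change, so nothing here sizes it directly. Because compound 1 gives 90.7% near the top of the read-out, a step of only modest size, most likely downward or none beyond the scatter, is expected in this assay. Compound 4 is expected to give 80%, within 55% to 95%. The expected step of a number 10.7 percentage points lower from compound 1 to compound 4 (beyond the scatter) is thus small.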

Compound 4, a percentage reported as inhibition, at one concentration (the size of the read-out at that concentration, not a potency): 65.5%
Compound 4: middle estimate off by 14.5 percentage points, on the high side, within the range that was stated.
By their numbers in this assay, from the lowest: compound 3; then compound 4; then compounds 1 and 2 (each within the scatter of the next).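

In this assay, within the data shown here, replacing 4-fluorophenyl with 4-methoxyphenyl gives a number 25.2 percentage points lower from compound 1 to compound 4 (beyond the scatter) and provides the first single-place comparison in this set. It shows that the result at this position on the aromatic ring depends on the group it carries, and that this one change, with the rest of the structure held constant, is enough to shift the read-out. No available evidence accounts for the step.

The compounds shown leave open how an amine, a hydroxyl or a longer alkoxy chain would read at this place. They also leave open whether methoxy in place of fluoro would give a similar step on compound 2.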